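Methyl at the amide-bound chain carbon of compound 3

A few compounds are considered here, and "the series" means these few. Any claim that something is new, unique, unknown or untested is made for them only; others in the source may bear on it.

Measured so far:
Compound 1, `O=C(C=C(c1ccccc1)c1ccccc1)NCCCCc1cccnc1`, gives 0.58 mg/kg in a functional assay with platelet-activating factor receptor (Cavia porcellus) as the target; a higher number here means that more compound is needed for the effect, a lower number that less compound is needed.
Compound 2, `CCCCC/C(=C/C=C/C(=O)N[C@H](C)CCCc1cccnc1)c1ccc(OC)cc1`, gives 0.78 mg/kg in this assay.
Compound 3, `COc1ccc(C(=C/C=C/C(=O)NCCCCc2cccnc2)c2ccc(OC)c(OC)c2)cc1OC`, gives 0.54 mg/kg in this assay.

Compound 3 has the lowest of the three numbers, yet its gaps to compound 1 and to compound 2 both lie within the scatter, so no order among the three can be claimed. Compound 4, `COc1ccc(C(=C/C=C/C(=O)N[C@H](C)CCCc2cccnc2)c2ccc(OC)c(OC)c2)cc1OC`, is not yet measured. It differs from compound 3 by one change: methyl in place of hydrogen on a saturated chain carbon bound to an amide-type nitrogen and a saturated chain carbon. Compound 2 carries the same methyl group on the same kind of chain carbon, with a different diaryl part, and its value sits within the scatter of compound 3 and compound 1. On that basis the step from compound 3 to compound 4 is expected to be small, a 1.1-fold higher number from compound 3 to compound 4 (0.06 log units; within the scatter), with no direction beyond the scatter. Compound 4 is therefore estimated at 0.62 mg/kg, in the range 0.3 mg/kg to 1.3 mg/kg.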

Compound 4, dose for 50% inhibition: 0.14 mg/kg
For compound 4 the middle estimate is 4.4-fold (0.65 log units) above the measured one, and the stated range ends above it.
By their numbers in this assay, from the lowest: compound 4; then compounds 3, 1 and 2 (each within the scatter of the next).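

Among the earlier compounds, methyl on this carbon occurred only in compound 2, which has no partner without it, so the change could not be read on its own. Within the data shown here, the pair of compound 3 and compound 4 isolates it: in this assay, methyl in place of hydrogen on the saturated chain carbon bound to an amide-type nitrogen and a saturated chain carbon gives a 3.9-fold lower number from compound 3 to compound 4 (0.59 log units; beyond the scatter) and is the first single change seen to go beyond the scatter. No measurement at hand bears on the cause of this step.

On these data alone, compound 4 shows one configuration at this carbon, so the outcome with the mirror-image arrangement stays open. Also open, as far as these compounds go, is whether ethyl or a longer chain on the same carbon would give a lower or a higher number than methyl does.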